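Phenylcarbamoylamino in Place of Dimethylamino on a Sulfonyl Sulfur

The source may hold more compounds than are shown below. What is called first, only, known or untested is meant among the compounds shown, and "the series" means these compounds.

Of the compounds shown here, three built on one shared core have been measured in a functional assay on the whole organism (trachea) with Rattus norvegicus as the target; on this read-out higher numbers stand for larger maximal responses and lower numbers for smaller maximal responses. Compound 1 `CCNS(=O)(=O)c1ccc2c(c1)C(n1ccccc1=O)=CC(C)(C)O2` gives 87%, compound 2 `CC1(C)C=C(n2ccccc2=O)c2cc(S(=O)(=O)Nc3ccc([N+](=O)[O-])cc3)ccc2O1` gives 75.6%, and compound 3 `CN(C)S(=O)(=O)c1ccc2c(c1)C(n1ccccc1=O)=CC(C)(C)O2` gives 74.1%. Compound 3 stands at the low end of the three numbers; its gap to compound 2 is within the scatter, and only compound 1 stands clearly higher. Two steps lead away from compound 1: a number 11.4 percentage points lower from compound 1 to compound 2 (beyond the scatter) and a number 12.9 percentage points lower from compound 1 to compound 3 (beyond the scatter). The third step, a number 1.5 percentage points lower from compound 2 to compound 3 (within the scatter), does not reach beyond the scatter.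

Compound 4 `CC1(C)C=C(n2ccccc2=O)c2cc(S(=O)(=O)NC(=O)Nc3ccccc3)ccc2O1` has not yet been measured. It differs from compound 3 in one place: (phenylcarbamoyl)amino in place of dimethylamino on a sulfonyl sulfur. Within the data shown here, the nearest precedent is the step in which a (4-nitrophenyl)amino group on the same sulfur was compared with dimethylamino, giving a number 1.5 percentage points lower from compound 2 to compound 3 (within the scatter). The entering group of compound 4 likewise carries a six-membered aromatic ring and hydrogen-bond donors, so no step beyond the scatter is expected in this assay, in either direction. Compound 4 is therefore estimated at 76%, with a range from 62% to 90%. This estimate corresponds to a number 1.9 percentage points higher from compound 3 to compound 4 (within the scatter) in this assay.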

Compound 4, largest response reached (Emax), in percent of the reference or control that the assay uses: 99.5%
For compound 4 the middle estimate is 23.5 percentage points below the measured one; the measured number lies above the stated range.
By their numbers in this assay, from the lowest: compounds 3 and 2 (each within the scatter of the next); then compound 1; then compound 4.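

In this assay, placing (phenylcarbamoyl)amino on the sulfonyl sulfur in place of dimethylamino gives a number 25.4 percentage points higher from compound 3 to compound 4 (beyond the scatter), so this position can raise the maximal response as well as lower it. An aromatic ring on the sulfonamide nitrogen cannot be the whole story: compound 2 also carries one, in its 4-nitrophenyl group, and stands within the scatter of compound 3, while replacing that group with phenylcarbamoyl gives a number 23.9 percentage points higher from compound 2 to compound 4 (beyond the scatter). Phenylcarbamoyl also outdoes the small ethyl group, with a number 12.5 percentage points higher from compound 1 to compound 4 (beyond the scatter), whereas the two earlier changes away from ethyl both gave lower numbers, and nothing available here explains this reversal.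

Still open, on these data alone, is which part of the entering group goes with the higher number: the carbonyl and its second nitrogen, or the phenyl ring at the far end. An acetyl or a methylcarbamoyl group on the sulfonamide nitrogen would help to separate these parts, and a benzoyl group would show what happens when the ring stays but that second nitrogen is gone.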